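The source may hold more compounds than are shown below. What is called first, only, known or untested is meant among the compounds shown, and "the series" means these compounds.

Compound 1 `Nc1ccc(C(=O)/C=C/c2ccc(Cl)cc2)cc1` gives 50% in a functional assay on the whole organism (strain albino) for inhibition, with Rattus norvegicus as the target, read by paw edema, with stated times of 30 min and 2 h, at a dose of 100 mg/kg by the oral route; on this read-out lower numbers stand for less inhibition and higher numbers for more inhibition at the one dose given (going by the name of the read-out).
Compound 2 `Nc1ccc(C(=O)/C=C/c2ccco2)cc1` gives 38%.
Compound 3 `COc1ccc(/C=C/C(=O)c2ccc(NC(=O)CBr)cc2)cc1` gives 42%.

Among these three numbers compound 2 sits at the low end. Compound 3 is closest to it, and the gap between the two lies within the usual scatter of this assay, so nothing can be said about their order. Compound 1 stands furthest away, and that gap lies beyond the scatter.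

Compound 4 `O=C(CO[N+](=O)[O-])Nc1ccc(C(=O)/C=C/c2ccco2)cc1` has not yet been measured. It differs from compound 2 in one place: ((nitrooxy)methyl)carbonyl in place of hydrogen on a nitrogen on an aromatic ring. For the measured compounds named here, no step between two measured compounds that differ in a single place is available, so the expectation rests on little. Compound 3, which also carries a carbonyl-bearing group on the ring nitrogen, gives 42% in this assay, close to compound 2. The change from compound 2 to compound 4 is therefore expected to give a small shift, a number 7 percentage points higher from compound 2 to compound 4 (within the scatter), within the scatter. For compound 4 the estimate is 45%, with a range from 32% to 58%.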

Compound 4, a percentage reported as inhibition, in the whole organism at one dose (the size of the read-out at that dose, not a potency): 36%
Beside the measured number, compound 4's estimate is 9 percentage points above it; the range from low to high includes it.
By their numbers in this assay, from the lowest: compounds 4, 2, 3 and 1 (each within the scatter of the next, the first and the last beyond it).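

For the compounds shown here, this is the first comparison in the set that isolates a single place: ((nitrooxy)methyl)carbonyl in place of hydrogen on a nitrogen on an aromatic ring gives a number 2 percentage points lower from compound 2 to compound 4 (within the scatter) in this assay on the core of compound 2. The ring nitrogen therefore takes this acylating group, with its 7 heavy atoms, without a change that can be told from scatter, so the hydrogen it replaces is not shown to matter for this read-out at the one dose given. No measurement at hand bears on why the number stays within the scatter.

As far as these compounds go, whether plain acetyl, or a longer chain ending in a carboxylic acid, would behave the same on that nitrogen stays open. So does the effect of the same change on the core of compound 1.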